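The source may hold more compounds than are shown below. What is called first, only, known or untested is meant among the compounds shown, and "the series" means these compounds.

Of the compounds shown here, three sharing one core have been measured. In a functional assay on MCF-10A cells (Homo sapiens) for antiproliferative activity, with a stated time of 48 h (on this read-out lower numbers stand for an effect already at smaller amounts and higher numbers for an effect only at larger amounts of compound), compound 1 (`COc1ccc2nc(C)cc(NCc3ccccc3)c2c1`) gives 25900 nM and stands at the upper end of the set. Compound 2 (`COc1ccc2nc(C)cc(NCc3ccccc3F)c2c1`) gives 14000 nM and stays within the scatter of compound 1. For the measured compounds named here, compound 3 (`COc1ccc2nc(C)cc(NCc3ccc(C(F)(F)F)cc3)c2c1`) gives 7600 nM and is the one clear departure from compound 1.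

Compound 4 (`COc1ccc2nc(C)cc(NCc3cccc(CO)c3)c2c1`) is compound 1 with hydroxymethyl in place of hydrogen on an aromatic carbon, meta to a large group (hydroxymethyl in place of hydrogen on an aromatic carbon).

Going by the values given here, two measured steps bear on this change, as each also replaces hydrogen on an aromatic carbon. Fluoro gives a 1.9-fold lower number from compound 1 to compound 2 (0.27 log units; within the scatter) and trifluoromethyl gives a 3.4-fold lower number from compound 1 to compound 3 (0.53 log units; beyond the scatter) in the same read-out. Neither step introduces hydroxymethyl, so they offer only weak guidance here. A small move toward a lower number is expected, probably not beyond the scatter. The estimated change is a 1.6-fold lower number from compound 1 to compound 4 (0.21 log units; within the scatter) in this assay overall. The estimated value for compound 4 is 16000 nM with an expected range from 6000 nM to 40000 nM in this assay.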

Compound 4, half-maximal effective concentration: 17100 nM
Estimate against measurement, compound 4: 1.1-fold (0.03 log units) below; low and high end bracket the measured number.
By their numbers in this assay, from the lowest: compounds 3, 2, 4 and 1 (each within the scatter of the next, the first and the last beyond it).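

In this assay, hydroxymethyl on an aromatic carbon, meta to a large group, gives a 1.5-fold lower number from compound 1 to compound 4 (0.18 log units; within the scatter), so this read-out does not separate this change from plain hydrogen. For the compounds shown here, neither compound 2 nor compound 3 carries a group at this place, so compound 4 is the first sign that this place accepts a substituent bearing a hydrogen-bond donor and acceptor without a change beyond the scatter. Nothing measured here accounts for this result.

From the compounds shown here alone, whether an aminomethyl group, a carboxylic acid or a longer chain such as hydroxyethyl at this same place would stay as close to compound 1 remains open. Also open, going by these compounds, is how fluoro or trifluoromethyl would read at this place, and hydroxymethyl elsewhere on this ring.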